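The source may hold more compounds than are shown below. What is called first, only, known or untested is meant among the compounds shown, and "the series" means these compounds.

Series notes. Compound 1 `C/N=C(/S)C1=CC(C)(C)Oc2ccc([N+](=O)[O-])cc21` is measured in a functional assay (aorta) with Rattus norvegicus as the target (on this read-out higher numbers stand for an effect only at larger amounts of compound and lower numbers for an effect already at smaller amounts), at 1.35 nM. Compound 2 `C/N=C(/S)C1=CC(C)(C(F)(F)F)Oc2ccc([N+](=O)[O-])cc21` carries the change trifluoromethyl in place of methyl on a saturated ring carbon and in this assay gives 0.302 nM; the step is a 4.5-fold lower number from compound 1 to compound 2 (0.65 log units; beyond the scatter). Compound 3 `CNC(=O)C1=CC(C)(C(F)(F)F)Oc2ccc([N+](=O)[O-])cc21` in this assay gives 2.69 nM, and from compound 2 the step is an 8.9-fold higher number from compound 2 to compound 3 (0.95 log units; beyond the scatter). The values of compound 1 and compound 3 lie within the usual scatter of one another, so no order is read between them. The difference between the cores of compound 1 and compound 3 is not broken down here.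

Compound 4 `CNC(=O)C1=CC(C(F)(F)F)(C(F)(F)F)Oc2ccc([N+](=O)[O-])cc21` is not yet measured. It differs from compound 3 by trifluoromethyl in place of methyl on a saturated ring carbon. This is the same kind of change as that from compound 1 to compound 2, though the surroundings are described differently: the ring atom two bonds away bears a methylcarbamoyl group (4 heavy atoms) in compound 3 rather than a group of 4 heavy atoms as in compound 1. Among the compounds with values here, with only the single earlier step to go on, a step of about a 3.0-fold lower number from compound 3 to compound 4 (0.48 log units; beyond the scatter) is expected, resting on compound 1 to compound 2 showing a 4.5-fold lower number from compound 1 to compound 2 (0.65 log units; beyond the scatter). Compound 4 is therefore estimated at 0.9 nM in this assay, between 0.3 nM and 3 nM.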

Compound 4, half-maximal effective concentration: 1.48 nM
Estimate against measurement, compound 4: 1.6-fold (0.22 log units) below; the range from low to high includes it.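

In this assay, trifluoromethyl in place of methyl on a saturated ring carbon now gives a 1.8-fold lower number from compound 3 to compound 4 (0.26 log units; within the scatter). Set beside the earlier step, the size of this change cannot be told apart between the core of compound 1 and the core of compound 3: the same change on two cores in this assay, a 4.5-fold lower number (0.65 log units; beyond the scatter) from compound 1 to compound 2 and a 1.8-fold lower number (0.26 log units; within the scatter) from compound 3 to compound 4, 2.5-fold (0.39 log units) apart, within the scatter of two such steps. Within the data shown here, this is consistent with the change carrying over from one core to the other, but it does not establish a general rule: only two pairs bear on the question, and the step on the core of compound 3, taken alone, does not stand clear of the scatter, so no order is read between compound 3 and compound 4.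

On these data alone, it remains open whether an ethyl group or a longer chain on the same saturated ring carbon would fit alongside these two steps. As far as these compounds go, it also remains open how the change would read on a core with a carboxylic acid in place of the methylcarbamoyl group.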